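Replacing 2-methylphenyl with 3,4-dichlorophenyl on the ring nitrogen

This account rests on a few compounds, and the source may have more. Where it says the series, first, only, none or still open, it means among the compounds named here.

Three compounds with the same core differ only in the group on an amine nitrogen in a ring. In a functional assay on HCT-116 cells (Homo sapiens) for antiproliferative activity, read by MTT assay, with a stated time of 72 h (on this read-out higher numbers stand for weaker inhibition and lower numbers for stronger inhibition), compound 1 (`Nc1nc(N)c2cc(CSC(=S)N3CCN(C4CCCCC4)CC3)ccc2n1`) reads 8400 nM and compound 2 (`COc1ccc(N2CCN(C(=S)SCc3ccc4nc(N)nc(N)c4c3)CC2)cc1`) reads 2270 nM while compound 3 (`Cc1ccccc1N1CCN(C(=S)SCc2ccc3nc(N)nc(N)c3c2)CC1`) reads 11800 nM on the same scale. Compound 3 thus sits with compound 1 at the upper end of these numbers, the two lying within the scatter of each other, and it stands beyond the scatter from compound 2.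

Compound 4 (`Nc1nc(N)c2cc(CSC(=S)N3CCN(c4ccc(Cl)c(Cl)c4)CC3)ccc2n1`) carries a further change: 3,4-dichlorophenyl in place of 2-methylphenyl on an amine nitrogen in a ring. Among the measured compounds shown here, the only measured exchange of one substituted phenyl for another is a 5.2-fold higher number from compound 2 to compound 3 (0.72 log units; beyond the scatter) and it shows that such a swap can move this read-out beyond the scatter. The step of a 1.4-fold higher number from compound 1 to compound 3 (0.15 log units; within the scatter) stays within the scatter, whereas the step of a 3.7-fold lower number from compound 1 to compound 2 (0.57 log units; beyond the scatter) does not. For the measured compounds named here, no measured compound carries chlorine, so the entering group has no direct precedent here. With compound 3 at 11800 nM near the top of the measured span, the step expected in this assay is modest and toward a lower number, an estimated 2.4-fold lower number from compound 3 to compound 4 (0.37 log units; beyond the scatter) with wide uncertainty. Compound 4 is estimated at 5000 nM within an expected range of 1500 nM to 15000 nM on present evidence.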

Compound 4, half-maximal inhibitory concentration: 6680 nM
Estimate against measurement, compound 4: 1.3-fold (0.13 log units) below; measured number inside the range.
By their numbers in this assay, from the lowest: compound 2; then compounds 4, 1 and 3 (each within the scatter of the next).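

In this assay, among the compounds shown here, the first chlorine-bearing group on this nitrogen leaves the read-out within the scatter of the groups already there, with a 1.8-fold lower number from compound 3 to compound 4 (0.25 log units; within the scatter) and a 1.3-fold lower number from compound 1 to compound 4 (0.10 log units; within the scatter), so cyclohexyl, 2-methylphenyl and 3,4-dichlorophenyl cannot be told apart at this position. The substituted phenyl of compound 2 remains the exception, as a 2.9-fold higher number from compound 2 to compound 4 (0.47 log units; beyond the scatter) shows, and compound 2 now lies beyond the scatter from all three other compounds, so a substituted phenyl on this nitrogen does not by itself give the lower number. The data shown offer no measurement that would explain why 4-methoxyphenyl stands apart.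

On these data alone, it remains open whether the separation of compound 2 belongs to the methoxy group itself, or whether an ethoxy group, a hydroxyl or an amine on the phenyl ring would read with compound 2 or with the other three. Also open, as far as these compounds go, is whether a single chlorine would read differently from the two in 3,4-dichlorophenyl, and whether a pyridine ring in place of the phenyl would keep the number of compound 2.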